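Sulfonyl chain homologues: cytotoxicity working notes

The source may hold more compounds than are shown below. What is called first, only, known or untested is meant among the compounds shown, and "the series" means these compounds.

Values in a functional assay on Huh-7 cells (Homo sapiens) for cytotoxicity, read by MTT assay, with a stated time of 72 h; a lower number here means that less compound is tolerated, a higher number that more compound is tolerated:
Compound 1, `CS(=O)(=O)N1CCC2(CC1)OOC1(CCCCC1)OO2`: > 100 ug/mL, a limit of the assay.
Compound 2, `CCS(=O)(=O)N1CCC2(CC1)OOC1(CCCCC1)OO2`: > 100 ug/mL, a limit of the assay.
Compound 3, `CCCS(=O)(=O)N1CCC2(CC1)OOC1(CCCCCC1)OO2`: > 100 ug/mL, a limit of the assay.

The change from compound 1 to compound 2 is methyl in place of hydrogen on a saturated chain carbon bound to a sulfonyl sulfur. The step that the two limits leave unreadable from compound 1 to compound 2 cannot be read because the limit of > 100 ug/mL in this assay, at which 3 of the 3 values shown sit, covers both ends of it. Compound 3 differs from compound 1 in more than one place; the difference between the two cores is not broken down here. Compound 4, `CCCCS(=O)(=O)N1CCC2(CC1)OOC1(CCCCCC1)OO2`, is not yet measured. It differs from compound 3 by methyl in place of hydrogen on a saturated chain carbon, three bonds along the chain from a sulfonyl sulfur. This is the same kind of change as from compound 1 to compound 2, but not the same: there the methyl enters on a saturated chain carbon bound to a sulfonyl sulfur, here on a saturated chain carbon, three bonds along the chain from a sulfonyl sulfur. In this assay, going by the values given here, the step from compound 3 to compound 4 is expected to be a step that the limit leaves unreadable from compound 3 to compound 4, with compound 4 most likely again at a limit, because the limit of > 100 ug/mL in this assay, at which 3 of the 3 values shown sit, holds for every compound measured so far. Compound 4 is expected to give about 150 ug/mL, estimated between 70 ug/mL and 400 ug/mL.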

Compound 4, half-maximal cytotoxic concentration: > 100 ug/mL
Compound 4: a limit, no number (the forecaster's own chance of this, stated with the estimate: 85%); the middle value lies beyond the limit too.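

Compound 4 gives > 100 ug/mL, again a limit of the assay and not a number. No step from compound 3 to compound 4 can be read, because both compounds sit at the same limit: the limit of > 100 ug/mL in this assay, at which 4 of the 4 values shown sit.

The compounds shown leave open at what concentration any of them becomes cytotoxic, and whether the sulfonyl chains differ at all.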